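A few compounds are considered here, and "the series" means these few. Any claim that something is new, unique, unknown or untested is made for them only; others in the source may bear on it.

Compound 1 `Cc1nc(C(NC(=O)C(=O)Nc2ccc(F)c(Cl)c2)C2CCCCN2)sc1CO` was examined in an ADME assay on MT2 cells (Homo sapiens) for cytotoxicity, read by XTT assay, with a stated time of 4 days; a lower number here means that less compound is tolerated, a higher number that more compound is tolerated. In that assay compound 1 gives only a limit, > 77800 nM, not a number. Compound 2 `Cc1nc(C(NC(=O)C(=O)Nc2ccc(F)c(Cl)c2)C2CCCCN2)sc1CCO`, in this assay, gives 94700 nM. The step that the limit leaves unreadable from compound 1 to compound 2 cannot be sized because compound 1 sits at the limit of > 77800 nM in this assay, at which 1 of the 2 values shown sits. Compound 3 `Cc1nc(C(NC(=O)C(=O)Nc2ccc(C(F)(F)F)cc2)C2CCCCN2)sc1CO` differs from compound 1 by 4-(trifluoromethyl)phenyl in place of 3-chloro-4-fluorophenyl on an amide-type nitrogen. Among the compounds with values here, no measured step touches this change, so no shift beyond the usual scatter is expected. Compound 3 is therefore expected to give 90000 nM, within 45000 nM to 200000 nM, in this assay. This amounts to an expected step that the limit leaves unreadable from compound 1 to compound 3.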

Compound 3, half-maximal cytotoxic concentration: > 75500 nM
Compound 3: a limit, no number; the forecaster's own chance of this, stated with the estimate: 60%; the middle value is on the limit's open side.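

Within the data shown here, compound 1 and compound 3 both give only limits in this assay, so no step between them can be read. From the compounds shown here alone, whether 4-(trifluoromethyl)phenyl in place of 3-chloro-4-fluorophenyl shifts the half-maximal cytotoxic concentration stays open.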